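The Smaller Ring on the Amide: Compound 2 to Compound 4

A few compounds are considered here, and "the series" means these few. Any claim that something is new, unique, unknown or untested is made for them only; others in the source may bear on it.

Of the compounds shown here, three have been measured in an assay on HeLa cells for displacement of a labelled ligand from adenosine receptor A3 (Homo sapiens), read by scintillation counting, with a stated time of 180 min, tested at 10 uM; a higher number here means more inhibition at the concentration tested (going by the name of the read-out), a lower number less inhibition. Compound 1 `O=C(NC1CCCC1)c1cc2ccccc2oc1=O` gives 20%, compound 3 `COc1cccc2cc(C(=O)NC3CCCC3)c(=N)oc12` gives 20%, and compound 2 `N=c1oc2ccc(Br)cc2cc1C(=O)NC1CCCCC1` gives 8%, the lowest of the three numbers; its gaps to compound 1 and to compound 3 both lie beyond the scatter. Compound 4 `N=c1oc2ccc(Br)cc2cc1C(=O)NC1CCCC1` has not yet been measured. It differs from compound 2 in one place: cyclopentyl in place of cyclohexyl on an amide-type nitrogen. Going by the values given here, no measured pair differs only in this way, so no measured step guides the expectation, and compound 1 and compound 3 carry the cyclopentyl group on other cores. In this assay the step is expected to be small, a number 4 percentage points higher from compound 2 to compound 4 (within the scatter), and not beyond the scatter. Compound 4 is therefore estimated at 12%, with a range from 0% to 25%.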

Compound 4, a percentage reported as inhibition, at one concentration (the size of the read-out at that concentration, not a potency): 0%
The estimate for compound 4 lay 12 percentage points above the measured number; the measured number falls inside the stated range.
By their numbers in this assay, from the lowest: compounds 4 and 2 (each within the scatter of the next); then compounds 1 and 3 (each within the scatter of the next).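

In this assay the change from cyclohexyl to cyclopentyl on the amide-type nitrogen now has a measured step of its own, a number 8 percentage points lower from compound 2 to compound 4 (within the scatter) and so, on this shared core, the two rings cannot be told apart. Nothing available explains this result.
Still open, from the compounds shown here alone, is whether a longer chain, such as n-butyl, or a piperidine on this nitrogen would give a reading beyond the scatter. Also open, going by these compounds, is whether cyclohexyl and cyclopentyl would read alike on the cores of compound 1 and compound 3.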